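The source may hold more compounds than are shown below. What is called first, only, known or untested is meant among the compounds shown, and "the series" means these compounds.

Measured compounds:
- compound 1, `COC(=O)C1=CO[C@@H](O[C@@H]2O[C@H](COC(c3ccccc3)(c3ccccc3)c3ccccc3)[C@@H](OC(=O)O)[C@H](OC(C)=O)[C@H]2OC(C)=O)[C@@H]2[C@@H](C)[C@@H](OC(C)=O)C[C@H]12` — 1.2 ug/mL
- compound 2, `COC(=O)C1=CO[C@@H](O[C@@H]2O[C@H](CO)[C@@H](OC(C)=O)[C@H](OC(C)=O)[C@H]2OC(C)=O)[C@@H]2[C@@H](C)[C@@H](OC(C)=O)C[C@H]12` — "not active" (no number reported)
- compound 3, `CCCCCCCCCCCCCCCC(=O)OC[C@H]1O[C@@H](O[C@@H]2OC=C(C(=O)OC)[C@H]3C[C@H](OC(C)=O)[C@H](C)[C@@H]23)[C@H](OC(C)=O)[C@@H](OC(C)=O)[C@@H]1OC(C)=O` — "not active" (no number reported)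

The series shares one core with a sugar carrying several acetyl groups, and the three measured compounds differ in what sits on the primary oxygen of that sugar. In a functional assay on PA-1 cells (Homo sapiens) for cytotoxicity, read by MTT assay, with a stated time of 4 h (a higher number here means a weaker inhibitor, a lower number a stronger inhibitor), compound 1 gives 1.2 ug/mL. Compound 2, the free hydroxymethyl analogue, gives "not active" (no number reported) in this assay, so no number stands for it; the same holds for compound 3 with its long-chain ester, which gives "not active" (no number reported) in this assay. Compound 2 thus stands among the entries without a number, with only compound 1 carrying a value.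

The step to compound 4, `C=CC(=O)OC[C@H]1O[C@@H](O[C@@H]2OC=C(C(=O)OC)[C@H]3C[C@H](OC(C)=O)[C@H](C)[C@@H]23)[C@H](OC(C)=O)[C@@H](OC(C)=O)[C@@H]1OC(C)=O`, is vinylcarbonyl in place of hydrogen on an oxygen on a saturated carbon. Within the data shown here, no measured pair shows this kind of change, so the size of the step cannot be read from the data. Of the two esters and the free hydroxyl, only the bulky ether of compound 1 has a number; the ester of compound 3 does not. The expectation is therefore no step beyond the scatter in this assay, with a real chance that compound 4 again returns only an inactive call. Compound 4 is estimated at 30 ug/mL, range 8 ug/mL to 120 ug/mL.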

Compound 4, half-maximal inhibitory concentration: "not active" (no number reported)
For compound 4 the study gives words and no number; the estimate stays without a comparison.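

In this assay compound 4, like compound 2 and compound 3, is reported only as "not active", so no step can be read from compound 2 to compound 4. Nothing measured here bears on a cause for this result. The compounds shown leave open how large the change from hydrogen to vinylcarbonyl on that oxygen is in this assay.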